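Compound 1 to compound 3: methyl on the nitrogen

The source may hold more compounds than are shown below. What is called first, only, known or untested is meant among the compounds shown, and "the series" means these compounds.

Compound 1 `Nc1nc(N)c2nc(Nc3ccccc3)ccc2n1` gives 1530 nM in an ADME assay on isolated protein for inhibition of Dihydrofolate reductase (Homo sapiens), using NADPH (on this read-out lower numbers stand for stronger inhibition and higher numbers for weaker inhibition), the lowest of the two numbers recorded; its nearest neighbour is compound 2 `Cc1ccc(Nc2ccc3nc(N)nc(N)c3n2)cc1`, which in this assay gives 2630 nM. The step of a 1.7-fold higher number from compound 1 to compound 2 (0.24 log units; within the scatter) puts a methyl in place of hydrogen on an aromatic carbon and stays within the scatter. Compound 3 `CN(c1ccccc1)c1ccc2nc(N)nc(N)c2n1` differs from compound 1 by methyl in place of hydrogen on a nitrogen on an aromatic ring. Within the data shown here, no measured pair shows a methyl entering on a nitrogen on an aromatic ring, so the only step that bears on this change, from compound 1 to compound 2, is indirect and small. On that basis compound 3 is expected to move little, if at all, beyond the scatter, with the expected step of a 1.6-fold higher number from compound 1 to compound 3 (0.21 log units; within the scatter) tending toward a higher number. The estimate for compound 3 in this assay is 2500 nM, expected to fall between 900 nM and 7000 nM.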

Compound 3, half-maximal inhibitory concentration: 942 nM
Beside the measured number, compound 3's estimate is 2.7-fold (0.42 log units) above it, within the range that was stated.
By their numbers in this assay, from the lowest: compounds 3, 1 and 2 (each within the scatter of the next, the first and the last beyond it).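

Methyl in place of hydrogen on a nitrogen on an aromatic ring gives the first direct reading at this position: in this assay the change is a 1.6-fold lower number from compound 1 to compound 3 (0.21 log units; within the scatter), so in this one pair the hydrogen on this nitrogen gives way to methyl without a step beyond the scatter. Among these compounds, the only earlier change, methyl on an aromatic carbon, is a 1.7-fold higher number from compound 1 to compound 2 (0.24 log units; within the scatter), so neither methyl step leaves the scatter. No measurement at hand accounts for either result.

The compounds shown leave open whether the step stays this small with ethyl, a longer chain or an acetyl group on this nitrogen. They also leave open how methyl on the nitrogen and methyl on the aromatic carbon would read together in one compound.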